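Chloro in Place of Methoxy: Expected Cytotoxicity of Compound 3

The source may hold more compounds than are shown below. What is called first, only, known or untested is meant among the compounds shown, and "the series" means these compounds.

Of the compounds shown here, two have so far been measured in a functional assay on BEL-7404 cells (Homo sapiens) for cytotoxicity, read by MTT assay, with a stated time of 72 h; on this read-out lower numbers stand for stronger inhibition and higher numbers for weaker inhibition. Compound 1 `O=C(/C=C/c1ccccc1)NNC(=O)c1ccccc1O` gives 21200 nM in this assay, while compound 2 `COCOc1cc(/C=C/C(=O)OCC(=O)Nc2ccc(OC)cc2)ccc1OCc1ccccc1` gives 133000 nM in this assay, the higher of the two numbers; its nearest neighbour is compound 1, whose number is lower by more than the usual scatter. Within the data shown here, the two compounds do not differ in a single place, so no step between measured compounds can be read.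

Compound 3 `COCOc1cc(/C=C/C(=O)OCC(=O)Nc2ccc(Cl)cc2)ccc1OCc1ccccc1` differs from compound 2 in one place only: chloro in place of methoxy on an aromatic carbon. Among the measured compounds shown here, nothing measured so far bears directly on that exchange. The expected step of a 1.3-fold lower number from compound 2 to compound 3 (0.12 log units; within the scatter) is therefore slight, leaning toward lower numbers but not clearly beyond the scatter. For compound 3 the estimated value in this assay is 100000 nM, with a range from 40000 nM to 250000 nM.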

Compound 3, half-maximal inhibitory concentration: > 200000 nM
Compound 3 ended at the assay's limit; the forecaster's own chance of this, stated with the estimate: 10%; middle value at least 2.0-fold (0.30 log units) from the limit.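

Among these compounds, this is the first step that can be read at this place, on an aromatic carbon para to a large group: in this assay, chloro in place of methoxy gives an at least 1.5-fold higher number from compound 2 to compound 3 (0.17 log units; that floor lies within the scatter). The floor of that step lies within the scatter, so a clear loss of inhibition is not established, yet the exchange brings no lower number and offers no gain over methoxy at this place. Going by these compounds, compound 3 stands at a limit of the assay and not at a number, and the full size of the step therefore stays unknown: the limit of > 200000 nM in this assay, at which 1 of the 3 values shown sits.

The compounds shown leave open whether an amine or a hydroxyl at this same place would bring the number down. They also leave open whether any such exchange would read differently on a core without the methoxymethyl and benzyl ethers.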